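The source may report more compounds than this note shows. Statements on the series, on what has been measured and on what is new or still open speak of the compounds shown alone.

Measured so far:
- compound 1 `O=C(Nc1ccc(Sc2nc3ccccc3s2)cc1)c1cc(Br)cc(Br)c1O`: in an ADME assay on HEK293 cells (Homo sapiens) for cytotoxicity, read by reporter gene assay and resazurin assay, with a stated time of 48 h (on this read-out higher numbers stand for lower toxicity in this test and lower numbers for higher toxicity in this test), compound 1 gives 66000 nM
- compound 2 `O=C(Nc1ccc(Sc2nc3ccccc3s2)c(Cl)c1)c1ccccc1O`: in this assay compound 2 gives 64000 nM
- compound 3 `COc1c(Br)cc(Br)cc1C(=O)Nc1ccccc1`: in this assay compound 3 gives only a limit, > 100000 nM

Among the two compounds with an actual number, compound 1 holds the higher one, yet its value and that of compound 2 are so close that they fall within the usual scatter, so neither can be called less toxic than the other. Compound 3 sits at the limit of the assay (the limit of > 100000 nM in this assay, at which 1 of the 3 values shown sits), so it yields no number to compare.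

The step of interest leads from compound 1 to compound 4 `COc1ccc(Br)cc1C(=O)Nc1ccc(Sc2nc3ccccc3s2)cc1`, which has not yet been measured. The change is 5-bromo-2-methoxyphenyl in place of 3,5-dibromo-2-hydroxyphenyl on a carbonyl carbon. For the measured compounds named here, no measured pair differing only in this way is available, so the expected size of the step rests on the three values alone, all of which lie at or near the high end of the measured range. In this assay the step of a 1.2-fold higher number from compound 1 to compound 4 (0.08 log units; within the scatter) is expected to be small, within the scatter, or at most a modest rise. Compound 4 is therefore estimated at 80000 nM, with a likely range from 40000 nM to 160000 nM.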

Compound 4, half-maximal cytotoxic concentration: > 100000 nM
Compound 4 was reported as a limit; the forecaster's own chance of this, stated with the estimate: 40%; middle value at least 1.2-fold (0.09 log units) away from the limit.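

Replacing 3,5-dibromo-2-hydroxyphenyl with 5-bromo-2-methoxyphenyl on a carbonyl carbon gives, in this assay, an at least 1.5-fold higher number from compound 1 to compound 4 (0.18 log units; that floor lies within the scatter). For the compounds shown here, this is the first reading of a change at this place, and it shows that this swap does not lower the number, although that floor does not establish a real rise. The size of the step cannot be fixed because the result for compound 4 is a limit: the limit of > 100000 nM in this assay, at which 2 of the 4 values shown sit.

The step also combines two changes, as the hydrogen-bond donor goes and the bromine count falls, and the compounds shown cannot separate them. From the compounds shown here alone, how an amine or a carboxylic acid on this carbonyl carbon's aromatic ring would read in this assay remains open.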